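Methoxy in Place of Hydrogen: From Compound 2 to Compound 4

A few compounds are considered here, and "the series" means these few. Any claim that something is new, unique, unknown or untested is made for them only; others in the source may bear on it.

Measured compounds:
compound 1, `COc1cc(-c2cc(/C=C/C(=O)c3ccc(N)cc3)[nH]n2)cc(OC)c1OC`: 94%
compound 2, `COc1ccc(C(=O)/C=C/c2cc(-c3cc(OC)c(OC)c(OC)c3)n[nH]2)cc1OC`: 93%
compound 3, `COc1cc(-c2cc(/C=C/C(=O)c3ccc(F)c(F)c3)[nH]n2)cc(OC)c1OC`: 87%
compound 4, `COc1cc(C(=O)/C=C/c2cc(-c3cc(OC)c(OC)c(OC)c3)n[nH]2)cc(OC)c1OC`: not yet measured

In a functional assay on SNB-19 cells (Homo sapiens) for cytotoxicity, read by sulforhodamine B assay, with a stated time of 48 h, tested at 0.1 uM (a lower number here means a stronger effect, a higher number a weaker effect of the compound at the concentration tested), compound 2 stands second highest of the three numbers. Its nearest neighbour is compound 1, reached by a number 1 percentage points lower from compound 1 to compound 2 (within the scatter); its furthest is compound 3, reached by a number 6 percentage points lower from compound 2 to compound 3 (within the scatter). The step to compound 4 is methoxy in place of hydrogen on an aromatic carbon.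

Going by the values given here, none of the measured steps matches this change directly: each of them exchanges the whole aryl group on the carbonyl carbon. Still, all three of them, a number 1 percentage points lower from compound 1 to compound 2 (within the scatter), a number 7 percentage points lower from compound 1 to compound 3 (within the scatter) and a number 6 percentage points lower from compound 2 to compound 3 (within the scatter), stay within the scatter, so the numbers in this assay have so far been insensitive to what sits on that ring. The addition of one methoxy is a smaller change than any of those, and no step beyond the scatter is expected for it in this assay.

Compound 4 is therefore estimated at 93%, between 85% and 99%, which means an expected step of no change at the digits printed from compound 2 to compound 4 (within the scatter).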

Compound 4, a percentage reported as activity, at one concentration (the size of the read-out at that concentration, not a potency): 90%
The estimate for compound 4 lay 3 percentage points above the measured number, within the range that was stated.
By their numbers in this assay, from the lowest: compounds 3, 4, 2 and 1 (each within the scatter of the next).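

Unlike the earlier steps, which exchange the whole aryl group on the carbonyl carbon, this change adds one methoxy at a single position, ortho to a methoxy group and meta to a large group. In this assay it gives a number 3 percentage points lower from compound 2 to compound 4 (within the scatter), so the insensitivity to this ring seen with the whole-group exchanges also holds for this smaller change at one defined position. Nothing available explains this behaviour.

As far as these compounds go, whether a different group at this position, such as an amine, a carboxylic acid or a longer chain, would move the number beyond the scatter remains open. From the compounds shown here alone, it is also open whether compound 2 and compound 4 would separate at a concentration other than the one used here.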